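Chloro in place of fluoro on the aryl of compound 1

A few compounds are considered here, and "the series" means these few. Any claim that something is new, unique, unknown or untested is made for them only; others in the source may bear on it.

Measured compounds:
Compound 1 `O=C1CCC2(c3ccc(F)cc3)OCCCN12` — 100 mg/kg
Compound 2 `Cc1ccc(C23CCC(=O)N2CCCO3)c(C)c1` — 150 mg/kg
Compound 3 `O=C(CCC(=O)c1ccc(F)cc1)NCCCO` — 500 mg/kg

In a functional assay on the whole organism (Central nervous system) with Mus musculus as the target (on this read-out lower numbers stand for an effect already at smaller amounts and higher numbers for an effect only at larger amounts of compound), compound 1 gives the lowest of the three numbers. Compound 2 stands next to it, higher only by an amount within the usual scatter, so the two cannot be separated on these data. Within the data shown here, compound 3, the open-chain relative of the shared core, gives the highest number, and its distance from compound 1 lies beyond the scatter; it is the only member of the set that is clearly set apart.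

Compound 4 `O=C1CCC2(c3ccc(Cl)cc3)OCCCN12` has not yet been measured. It differs from compound 1 by a single substitution: chloro in place of fluoro on an aromatic carbon. Among the measured compounds shown here, no step between two measured compounds covers this kind of change, so there is no direct precedent; the ring core, the lactam and the oxygen-containing ring are all kept as in compound 1.

For compound 4 the step in this assay is expected to stay within the scatter, with at most a slight shift toward a smaller number, giving a 1.2-fold lower number from compound 1 to compound 4 (0.07 log units; within the scatter) as the estimated step. The number expected for compound 4 is 85 mg/kg, with a range from 40 mg/kg to 200 mg/kg.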

Compound 4, dose for half-maximal effect: 81.2 mg/kg
Compound 4: middle estimate off by 1.0-fold (0.02 log units), on the high side, and the stated range covers the measured number.
By their numbers in this assay, from the lowest: compounds 4, 1 and 2 (each within the scatter of the next); then compound 3.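

In this assay, among these compounds, the exchange of chloro for fluoro on an aromatic carbon, para to a large group, gives the first step that can be read at this position: a 1.2-fold lower number from compound 1 to compound 4 (0.09 log units; within the scatter). Among the compounds shown here, the earlier compounds offered no step between two measured compounds, so this single pair is the only direct reading on the aryl substituent, and it shows that this exchange of one heavy atom for another, with no hydrogen-bond donor, hydrogen-bond acceptor or net charge entering or leaving, stays within the scatter in the core of compound 1. No measured information is available that would account for this result or bear on it.

Going by these compounds, both groups seen at this position are single halogen atoms, so it remains open whether a group of another kind there, such as an amine, a carboxylic acid or a longer chain, would also stay within the scatter of compound 1. For the compounds shown here, also open is whether chloro in place of fluoro would give a similar step in the open-chain form of compound 3, the one compound clearly set apart from compound 1.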